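Trimethoxyphenyl cinnamamide: expected cytotoxicity on neuroblastoma cells

The compounds below may be only part of what the source reports. "The series", "measured", "known", "first", "only" and "open" are said of these compounds alone.

Measured compounds:
Compound 1, `COc1ccc(/C=C/C(=O)NCc2ccc(OCc3nc(C)c(C)nc3C)c(OC)c2)cc1O`, 8560 nM
Compound 2, `COc1cc(CNC(=O)/C=C/c2ccc(OC)c(OCc3nc(C)c(C)nc3C)c2)ccc1OCc1nc(C)c(C)nc1C`, 11600 nM
Compound 3, `COc1cc(CNC(=O)/C=C/c2cc(OC)c(OC)c(OC)c2)ccc1O`, 5910 nM

In a functional assay on SH-SY5Y cells (Homo sapiens) for cytotoxicity, read by MTT assay, with stated times of 24 h and 4 h (a lower number here means that less compound is needed, a higher number that more compound is needed for the effect), compound 1 gives 8560 nM. Of the three numbers, its nearest neighbour is compound 2 and its furthest is compound 3, and both gaps lie within the scatter, so the three compounds cannot be ranked. Among the compounds with values here, the one single-point step, a 1.4-fold higher number from compound 1 to compound 2 (0.13 log units; within the scatter), shows that adding a (3,5,6-trimethylpyrazin-2-yl)methyl group on the phenol oxygen leaves the read-out essentially unchanged. Compound 3 differs from compound 1 in two places and its value sits close to both others.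

Compound 4, `COc1cc(CNC(=O)/C=C/c2ccc(OC)c(OC)c2OC)ccc1OCc1nc(C)c(C)nc1C`, differs from compound 1 as follows: 2,3,4-trimethoxyphenyl in place of 3-hydroxy-4-methoxyphenyl on a double-bonded chain carbon bound to a double-bonded chain carbon. Within the data shown here, no measured step bears directly on this exchange; the only available step is that from compound 1 to compound 2, which is within the scatter, and compound 3, which also carries three methoxy groups on the double-bonded chain, gives a number close to compound 1. Compound 4 is therefore expected to change little, a 1.1-fold lower number from compound 1 to compound 4 (0.03 log units; within the scatter). The estimate for compound 4 is 8000 nM, within 3500 nM to 18000 nM.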

Compound 4, half-maximal effective concentration: 3840 nM
The estimate for compound 4 lay 2.1-fold (0.32 log units) above the measured number, within the range that was stated.
By their numbers in this assay, from the lowest: compounds 4, 3, 1 and 2 (each within the scatter of the next, the first and the last beyond it).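

Within the data shown here, the aryl group on a double-bonded chain carbon bound to a double-bonded chain carbon is the first place where a single exchange moves the number in this assay beyond the scatter, if only modestly: a 2.2-fold lower number from compound 1 to compound 4 (0.35 log units; beyond the scatter). The earlier step, on the phenol oxygen, had stayed within the scatter, so this result shows that the read-out can respond to a change at this other place. Nothing measured here explains the shift.

The exchange removes the hydroxy group and brings in the 2,3,4-trimethoxyphenyl pattern in a single step, so the compounds shown do not separate these two changes. They also leave open how the number would respond to an amine or a carboxylic acid on this aromatic ring.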